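A few compounds are considered here, and "the series" means these few. Any claim that something is new, unique, unknown or untested is made for them only; others in the source may bear on it.

Going by the values given here, in an ADME assay on microsomes (Homo sapiens) for metabolic stability (on this read-out higher numbers stand for fast clearance and lower numbers for slow clearance), compound 1 (`CNC(=O)[C@@H]1CCCN1S(=O)(=O)c1ccc(Cl)c(COc2cccc3c(-n4ccnc4)cc(C)nc23)c1Cl`) gives 33.3 mL/min/kg and stands lowest of the two numbers so far. Compound 2 (`Cc1cc(C(F)(F)F)c2cccc(OCc3c(Cl)ccc(S(=O)(=O)N4CC[C@@H](N(C)C)C4)c3Cl)c2n1`) gives 167 mL/min/kg as its number, higher by more than the usual scatter. Compound 3 (`CNC(=O)[C@@H]1CCCN1S(=O)(=O)c1ccc(Cl)c(COc2cccc3c(-c4cccnc4)cc(C)nc23)c1Cl`) keeps the core of compound 1 but has pyridin-3-yl in place of 1H-imidazol-1-yl on an aromatic carbon. Among the compounds with values here, no measured pair shows this swap, so the expected step of a 1.2-fold higher number from compound 1 to compound 3 (0.08 log units; within the scatter) is only a slight rise that stays within the scatter. On this assay compound 3 is estimated at 40 mL/min/kg with 18 mL/min/kg to 90 mL/min/kg as its expected range.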

Compound 3, clearance: 233 mL/min/kg
Estimate against measurement, compound 3: 5.8-fold (0.77 log units) below; the measured number lies above the stated range.
By their numbers in this assay, from the lowest: compound 1; then compounds 2 and 3 (each within the scatter of the next).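

In this assay, pyridin-3-yl in place of 1H-imidazol-1-yl on this aromatic carbon brings a 7.0-fold higher number from compound 1 to compound 3 (0.84 log units; beyond the scatter). Clearance at this position therefore depends strongly on which aromatic ring is attached, even though neither ring carries a net charge or a hydrogen-bond donor. Nothing available explains why the number rises.

On these data alone, it remains open whether this high clearance is specific to pyridin-3-yl or extends to other six-membered rings such as phenyl. A small group such as an amine on this carbon could also give a different result.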